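Pyridin-3-yl in place of pyridin-2-yl: notes on the series

This account rests on a few compounds, and the source may have more. Where it says the series, first, only, none or still open, it means among the compounds named here.

In a functional assay on A498 cells (Homo sapiens) for antiproliferative activity (on this read-out higher numbers stand for weaker inhibition of growth and lower numbers for stronger inhibition of growth), compound 1 `c1ccc(-c2cc(-c3ccco3)cc(-c3ccccn3)n2)nc1` gives 0.000064 ug/mL and compound 2 `c1ccc(-c2cc(-c3cccs3)cc(-c3ccccn3)n2)nc1` gives 0.000097 ug/mL. These two values lie within the scatter of each other, so compound 2 stands level with compound 1. For the measured compounds named here, the only measured step is a 1.5-fold higher number from compound 1 to compound 2 (0.18 log units; within the scatter), with thiophen-2-yl in place of furan-2-yl. Compound 3 `c1ccc(-c2cc(-c3cccs3)cc(-c3cccnc3)n2)nc1` keeps thiophen-2-yl and carries pyridin-3-yl in place of pyridin-2-yl on an aromatic carbon. The measured step concerns another group, so it sets no size for this change, and neither measured compound carries pyridin-3-yl. Both carry pyridin-2-yl at this place, which leaves the direction a judgement, and weaker inhibition of growth is expected. The estimated step is a 100-fold higher number from compound 2 to compound 3 (2.01 log units; beyond the scatter) in this assay, with wide uncertainty. For compound 3 the estimate is 0.01 ug/mL, with an expected range of 0.0004 ug/mL to 0.5 ug/mL.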

Compound 3, concentration for 50% growth inhibition: 0.0029 ug/mL
Compound 3: the middle estimate sits 3.4-fold (0.54 log units) above what was measured, and the stated range covers the measured number.
By their numbers in this assay, from the lowest: compounds 1 and 2 (each within the scatter of the next); then compound 3.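

In this assay, this position on the ring carrying the thiophen-2-yl group turns out to be sensitive to how the pyridine is joined: a 30-fold higher number from compound 2 to compound 3 (1.48 log units; beyond the scatter), a large step, whereas the earlier furan-2-yl to thiophen-2-yl exchange stayed within the scatter. Pyridin-2-yl and pyridin-3-yl have the same atoms joined differently, so in this pair the connectivity of the group next to the ring nitrogen alone accompanies the loss of growth inhibition. Nothing shown here accounts for the size of this step.

The compounds shown leave open whether the step keeps its size with furan-2-yl in place of thiophen-2-yl, since this change is seen in one pair only. They also leave open how pyridin-4-yl or a plain phenyl ring would read at this place.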